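The source may report more compounds than this note shows. Statements on the series, on what has been measured and on what is new or still open speak of the compounds shown alone.

Measured compounds in an assay on HEK293 cells for displacement of a labelled ligand from 5-hydroxytryptamine receptor 7 (Rattus norvegicus); on this read-out higher numbers stand for weaker inhibition and lower numbers for stronger inhibition: compound 2 `O=C(CCCCCN1CCN(c2ccccc2-c2ccccc2)CC1)NC1CCCc2ccccc21` gives 0.13 nM; compound 3 `CNc1ccccc1N1CCN(CCCCCC(=O)NC2CCCc3ccccc32)CC1` gives 25.4 nM; compound 1 `CCCCc1ccccc1N1CCN(CCCCCC(=O)NC2CCCc3ccccc32)CC1` gives 2810 nM.

Compound 2 stands lowest of the three numbers; its nearest neighbour is compound 3, a 200-fold higher number from compound 2 to compound 3 (2.29 log units; beyond the scatter), and the furthest is compound 1, a 22000-fold lower number from compound 1 to compound 2 (4.33 log units; beyond the scatter). Compound 4 `O=C(CCCCCN1CCN(c2cccc[n+]2[O-])CC1)NC1CCCc2ccccc21` is not yet measured; it differs from compound 2 by a group of 7 heavy atoms (5 carbon, 1 nitrogen, 1 oxygen; one six-membered aromatic ring with 1 hetero atom) in place of a group of 12 heavy atoms (12 carbon; 2 six-membered aromatic rings of carbon only), on an amine nitrogen in a ring. Within the data shown here, the steps that bear on this are the losses of the 2-phenylphenyl group seen in a 200-fold higher number from compound 2 to compound 3 (2.29 log units; beyond the scatter) and a 22000-fold lower number from compound 1 to compound 2 (4.33 log units; beyond the scatter), both large. A large step upward in this assay is therefore expected, and the estimate for compound 4 is 50 nM (range 5 nM to 500 nM), meaning an expected 380-fold higher number from compound 2 to compound 4 (2.59 log units; beyond the scatter).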

Compound 4, inhibition constant: 8030 nM
For compound 4 the middle estimate is 160-fold (2.21 log units) below the measured one; the whole stated range lies below it.
By their numbers in this assay, from the lowest: compound 2; then compound 3; then compound 1; then compound 4.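

In this assay, the group entering on the amine nitrogen in a ring gives the highest number of the four: a large rise against the aryl groups bearing phenyl (a 62000-fold higher number from compound 2 to compound 4 (4.79 log units; beyond the scatter)) and methylamino (a 320-fold higher number from compound 3 to compound 4 (2.50 log units; beyond the scatter)), and a modest one even against butyl (a 2.9-fold higher number from compound 1 to compound 4 (0.46 log units; beyond the scatter)). Thus, the single aromatic ring with one hetero atom and one hydrogen-bond acceptor retains neither low number seen at this position. Nothing available explains this rise. A plain pyridine ring without the oxygen would separate the ring nitrogen from the oxygen. On these data alone, a methoxy group in place of phenyl remains open as well.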